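Amide Aryl Variation on a Shared Core

A few compounds are considered here, and "the series" means these few. Any claim that something is new, unique, unknown or untested is made for them only; others in the source may bear on it.

In a functional assay on MDA-MB-231 cells (Homo sapiens) for inhibition, read by MTT assay, with a stated time of 72 h (on this read-out higher numbers stand for weaker inhibition and lower numbers for stronger inhibition), compound 1 `O=C(CSc1nc(Nc2ccccc2)c2ccccc2n1)Nc1cccc(F)c1` gives only a limit of the assay, > 50000 nM.
In this assay compound 2 `O=C(CSc1nc(Nc2ccccc2)c2ccccc2n1)Nc1cccc(Cl)c1` gives 16500 nM.
In this assay compound 3 `O=C(CSc1nc(Nc2ccccc2)c2ccccc2n1)Nc1ccc(Cl)cc1` gives 17200 nM.

Compound 2 holds the lowest of the two numbers measured, with compound 3 a mere a 1.0-fold higher number from compound 2 to compound 3 (0.02 log units; within the scatter) away. Compound 4 `O=C(CSc1nc(Nc2ccccc2)c2ccccc2n1)Nc1ccc(C(F)(F)F)cc1` differs from compound 2 by 4-(trifluoromethyl)phenyl in place of 3-chlorophenyl on an amide-type nitrogen. For the measured compounds named here, two measured steps bear on this: the move of chloro around the ring, a 1.0-fold higher number from compound 2 to compound 3 (0.02 log units; within the scatter), and the halogen swap, an at least 3.0-fold lower number from compound 1 to compound 2 (0.48 log units; beyond the scatter), which sits against a limit (the limit of > 50000 nM in this assay, at which 1 of the 3 values shown sits). Going by the values given here, no measured step covers trifluoromethyl itself, so the expected change is a 1.1-fold lower number from compound 2 to compound 4 (0.04 log units; within the scatter), a step not clearly beyond the scatter. Compound 4 is therefore estimated at 15000 nM, within 5000 nM to 45000 nM.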

Compound 4, half-maximal inhibitory concentration: 11100 nM
The estimate for compound 4 lay 1.4-fold (0.13 log units) above the measured number; low and high end bracket the measured number.
By their numbers in this assay, from the lowest: compounds 4, 2 and 3 (each within the scatter of the next). At a limit, above all of these: compound 1.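

On the amide-type nitrogen, 4-(trifluoromethyl)phenyl does not separate from either chlorophenyl in this assay: there is a 1.5-fold lower number from compound 2 to compound 4 (0.17 log units; within the scatter), and there is a 1.5-fold lower number from compound 3 to compound 4 (0.19 log units; within the scatter). Trifluoromethyl in place of chloro on this aromatic carbon thus leaves the number within the scatter. Compound 4 also parts from compound 1, with an at least 4.5-fold lower number from compound 1 to compound 4 (0.65 log units; beyond the scatter), so a group other than chloro now clears the 3-fluorophenyl compound, although this step rests on a limit: the limit of > 50000 nM in this assay, at which 1 of the 4 values shown sits.

On these data alone, whether an amine, a carboxylic acid or a methoxy group in place of trifluoromethyl would hold these numbers stays open.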